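The source may hold more compounds than are shown below. What is called first, only, known or untested is meant among the compounds shown, and "the series" means these compounds.

Three amides built on one shared core have been measured in a functional assay (Sus scrofa) with sulfonylurea receptors; K-ATP channels (Homo sapiens) as the target; on this read-out higher numbers stand for an effect only at larger amounts of compound and lower numbers for an effect already at smaller amounts. Compound 1 `CC(C)=CC(=O)Nc1c(C(O)(C(F)(F)F)C(F)(F)F)ccc2ccccc12` gives 550 nM, compound 2 `O=C(Nc1c(C(O)(C(F)(F)F)C(F)(F)F)ccc2ccccc12)C1CC1` gives 126 nM, and compound 3 `Cc1cccc(C(=O)Nc2c(C(O)(C(F)(F)F)C(F)(F)F)ccc3ccccc23)c1` gives 52.5 nM. Compound 3 stands at the lowest number of the three: the step of a 2.4-fold lower number from compound 2 to compound 3 (0.38 log units; beyond the scatter) and the step of a 10-fold lower number from compound 1 to compound 3 (1.02 log units; beyond the scatter) both lie beyond the scatter, so compound 3 is the most potent of the three on this read-out.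

Compound 4 `O=C(Nc1c(C(O)(C(F)(F)F)C(F)(F)F)ccc2ccccc12)c1ccc(Cl)cc1` differs from compound 3 in one place: 4-chlorophenyl in place of 3-methylphenyl on a carbonyl carbon. Going by the values given here, none of the measured steps exchanges one substituted phenyl ring for another. Among the compounds with values here, the two that bear on the new compound are a 2.4-fold lower number from compound 2 to compound 3 (0.38 log units; beyond the scatter) and a 10-fold lower number from compound 1 to compound 3 (1.02 log units; beyond the scatter); they show that a six-membered aromatic ring on the carbonyl carbon gave the lowest number so far, set against a cyclopropyl or a 2-methylprop-1-en-1-yl group, and compound 4 keeps such a ring. Within the data shown here, with no measured step on a methyl against a chlorine on that ring, no step beyond the scatter is expected for compound 4 in this assay, in either direction. The estimate for compound 4 is 50 nM, within 15 nM to 170 nM. That estimate corresponds to a 1.1-fold lower number from compound 3 to compound 4 (0.02 log units; within the scatter), a change expected to stay inside the scatter.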

Compound 4, half-maximal effective concentration: 389 nM
Compound 4: the middle estimate sits 7.8-fold (0.89 log units) below what was measured; measured number outside the range, above it.
By their numbers in this assay, from the lowest: compound 3; then compound 2; then compounds 4 and 1 (each within the scatter of the next).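

In this assay, swapping one substituted phenyl ring for another at the carbonyl carbon moves the number as far as any change among these amides: a 7.4-fold higher number from compound 3 to compound 4 (0.87 log units; beyond the scatter). A six-membered aromatic ring at this position therefore does not give a low number by itself, and the earlier ranking of aryl over smaller groups holds only for the 3-methylphenyl of compound 3, with a 3.1-fold higher number from compound 2 to compound 4 (0.49 log units; beyond the scatter) placing the 4-chlorophenyl against that trend, while a 1.4-fold lower number from compound 1 to compound 4 (0.15 log units; within the scatter) leaves it level with the 2-methylprop-1-en-1-yl group. Nothing available explains why the 4-chlorophenyl and the 3-methylphenyl differ so much here.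

The exchange alters both the substituent and its place on the ring, so these compounds leave open whether the methyl, the chlorine or their placing accounts for the step. They also leave open where a plain phenyl ring, or one carrying a methoxy group or a nitrile, would fall relative to compound 3 and compound 4.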